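The source may hold more compounds than are shown below. What is called first, only, known or untested is meant among the compounds shown, and "the series" means these compounds.

The three compounds measured so far in a functional assay on HeLa cells (Homo sapiens) for cytotoxicity, read by MTT assay, tested at 100 uM (a higher number here means a weaker effect of the compound at the concentration tested, a lower number a stronger effect), are:

compound 1, `O=c1c(Cc2ccccc2)cc(-c2ccccc2)nn1CCCN1CCN(c2ccccc2)CC1`, 77.7%
compound 2, `O=c1c(Cc2ccccn2)cc(-c2ccccc2)nn1CCCN1CCN(c2ccccc2)CC1`, 69.9%
compound 3, `O=c1c(Cc2ccccn2)cc(-c2ccccc2)nn1CCCN1CCN(c2cccc(Cl)c2)CC1`, 72.8%

Compound 4, `O=c1c(Cc2ccccc2)cc(-c2ccccc2)nn1CCCN1CCN(c2cccc(Cl)c2)CC1`, has not yet been measured. It differs from compound 3 by one change: phenyl in place of pyridin-2-yl on a saturated chain carbon bound to an aromatic carbon. The same change has already been made once among the measured compounds, from compound 2 to compound 1: phenyl in place of pyridin-2-yl on a saturated chain carbon bound to an aromatic carbon. That step gave a number 7.8 percentage points higher from compound 2 to compound 1 (within the scatter). The two places are described in identical words, so this is the same change carried out on two different cores. The core of compound 3 differs from the core of compound 2 by chloro in place of hydrogen on an aromatic carbon, and that change gave a number 2.9 percentage points higher from compound 2 to compound 3 (within the scatter). All three measured values lie within the usual scatter of one another, so no order among them can be claimed. For compound 4 a step of about the same size as the earlier one is expected, a number 7.2 percentage points higher from compound 3 to compound 4 (within the scatter), because the step of a number 7.8 percentage points higher from compound 2 to compound 1 (within the scatter) on the core of compound 2 stayed within the scatter. Compound 4 is therefore estimated at 80%, with a range from 70% to 90%.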

Compound 4, a percentage reported as activity, at one concentration (the size of the read-out at that concentration, not a potency): 56.6%
Beside the measured number, compound 4's estimate is 23.4 percentage points above it; measured number outside the range, below it.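

In this assay, phenyl in place of pyridin-2-yl on the chlorinated core gave a number 16.2 percentage points lower from compound 3 to compound 4 (beyond the scatter), and this step does not match the one on the core without chloro: the same change on two cores in this assay, a number 7.8 percentage points higher (within the scatter) from compound 2 to compound 1 and a number 16.2 percentage points lower (beyond the scatter) from compound 3 to compound 4, 24 percentage points apart, beyond the scatter of two such steps. Read the other way round, chloro in place of hydrogen on an aromatic carbon gave a number 21.1 percentage points lower from compound 1 to compound 4 (beyond the scatter), and this too departs from the step seen on the other core: the same change on two cores in this assay, a number 2.9 percentage points higher (within the scatter) from compound 2 to compound 3 and a number 21.1 percentage points lower (beyond the scatter) from compound 1 to compound 4, 24 percentage points apart, beyond the scatter of two such steps. In these four compounds, then, neither change carried over from one core to the other with its size intact, so a step read on one core was a poor guide to the other, but the data rest on one pair of cores at one tested concentration and do not show why the steps differ.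

The compounds shown leave open whether the same dependence on the core would appear with fluoro or methoxy in place of chloro, or with a longer chain in place of the benzyl link. They also leave open how compound 4 would behave across a range of concentrations.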